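The source may hold more compounds than are shown below. What is called first, only, known or untested is meant among the compounds shown, and "the series" means these compounds.

Measured so far:
Compound 1 `O=C(Nc1ccc(Br)cc1)N[C@H]1CC[C@H](Oc2ccc(F)cc2)CC1`: in a functional assay on CRL2813 cells (Homo sapiens) for cytotoxicity, read by sulforhodamine B assay, with a stated time of 5 days (on this read-out lower numbers stand for stronger inhibition and higher numbers for weaker inhibition), compound 1 gives > 20000 nM, which is a limit of the assay and not a number.
Compound 2 `O=C(Nc1cccc([N+](=O)[O-])c1)N[C@H]1CC[C@H](Oc2ccc(F)cc2)CC1`: in this assay compound 2 gives 6700 nM.
Compound 3 `O=C(Nc1cccc(Cl)c1)N[C@H]1CC[C@H](Oc2ccc(F)cc2)CC1`: in this assay compound 3 gives 5900 nM.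

Compound 1 thus stands only at the limit of > 20000 nM in this assay, at which 1 of the 3 values shown sits, with no measured number of its own. The step to compound 4 `COc1ccccc1NC(=O)N[C@H]1CC[C@H](Oc2ccc(F)cc2)CC1` is 2-methoxyphenyl in place of 4-bromophenyl on an amide-type nitrogen. Two measured steps remove the same group from the same amide-type nitrogen: an at least 2.9-fold lower number from compound 1 to compound 2 (0.47 log units; beyond the scatter) and an at least 3.3-fold lower number from compound 1 to compound 3 (0.53 log units; beyond the scatter). Both give lower numbers once 4-bromophenyl is gone, though each is known only as a bound on the side of compound 1. Between compound 2 and compound 3, a 1.1-fold lower number from compound 2 to compound 3 (0.06 log units; within the scatter), so the two entering groups are not told apart. For the measured compounds named here, no measured step says how 2-methoxyphenyl compares with 3-nitrophenyl or 3-chlorophenyl. For compound 4 a lower number than for compound 1 is expected, roughly an at least 2.2-fold lower number from compound 1 to compound 4 (0.34 log units; beyond the scatter), with less confidence than the two measured steps carry, the entering group being unlike either. The estimate for compound 4 is 9000 nM, in the range 3000 nM to 30000 nM.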

Compound 4, half-maximal inhibitory concentration: > 20000 nM
Compound 4: a limit, no number; the forecaster's own chance of this, stated with the estimate: 35%; middle value at least 2.2-fold (0.34 log units) from the limit.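

In this assay, compound 4 stands at a limit and not at a number, as compound 1 does, and the step between them cannot be read: the limit of > 20000 nM in this assay, at which 2 of the 4 values shown sit.

For the compounds shown here, replacing 4-bromophenyl on the amide-type nitrogen therefore does not by itself give a lower number; the result depends on the entering group, which the earlier compounds could not show. Set against the two entering groups that gave numbers, 2-methoxyphenyl gives an at least 3.3-fold higher number from compound 3 to compound 4 (0.53 log units; beyond the scatter) and an at least 2.9-fold higher number from compound 2 to compound 4 (0.47 log units; beyond the scatter), so this nitrogen tells these aryl groups apart even though 3-nitrophenyl and 3-chlorophenyl remain within the scatter of each other.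

As far as these compounds go, whether the identity of the ring substituent or its place on the ring decides the outcome stays open, as no single substituent appears here at two places. How an amine or a carboxylic acid on that phenyl would read is also unknown.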